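Swapping 3,4-dimethoxyphenyl for 4-fluorophenyl in a growth inhibitor

The source may report more compounds than this note shows. Statements on the series, on what has been measured and on what is new or still open speak of the compounds shown alone.

Among the measured compounds shown here, in a functional assay on Gurav cells (Homo sapiens) for inhibition, read by sulforhodamine B assay (a higher number here means a weaker inhibitor of growth, a lower number a stronger inhibitor of growth), compound 1 `COc1ccc(-c2ccc(-c3ccc(-c4nc5cc(C)ccc5[nH]4)cc3)cc2)cc1OC` gives 1310 nM, the middle of the three numbers measured so far. Compound 2 `COc1cc(-c2ccc(-c3ccc(-c4nc5cc(C)ccc5[nH]4)cc3)cc2)cc(OC)c1OC` gives 170 nM, and compound 3 `COc1ccc(-c2ccc(-c3ccc(-c4nc5ccccc5[nH]4)cc3)cc2)cc1OC` gives 9230 nM. Compound 4 `Cc1ccc2[nH]c(-c3ccc(-c4ccc(-c5ccc(F)cc5)cc4)cc3)nc2c1` has not yet been measured. It differs from compound 1 in one place: 4-fluorophenyl in place of 3,4-dimethoxyphenyl on an aromatic carbon. For the measured compounds named here, no measured step makes this exact change, and no measured compound carries fluorine, so the evidence is indirect. The closest step is methoxy in place of hydrogen on an aromatic carbon, which gave a 7.7-fold lower number from compound 1 to compound 2 (0.89 log units; beyond the scatter). Compound 4 goes the other way and has no methoxy at all, so a move to a higher number seems more likely than a move to a lower one. The step of a 7.0-fold higher number from compound 1 to compound 3 (0.85 log units; beyond the scatter), hydrogen in place of methyl on an aromatic carbon, shows that a small edit can also shift the number by a similar amount. The expected step is modest and uncertain: a 1.9-fold higher number from compound 1 to compound 4 (0.28 log units; within the scatter). For compound 4 the estimated value is 2500 nM, with an expected range of 500 nM to 10000 nM.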

Compound 4, concentration for 50% growth inhibition: 16500 nM
Estimate against measurement, compound 4: 6.6-fold (0.82 log units) below; measured number above the stated range.
By their numbers in this assay, from the lowest: compound 2; then compound 1; then compounds 3 and 4 (each within the scatter of the next).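

In this assay, placing 4-fluorophenyl where compound 1 has 3,4-dimethoxyphenyl gives a 13-fold higher number from compound 1 to compound 4 (1.10 log units; beyond the scatter), so this position, para to a large group, can weaken growth inhibition as well as strengthen it. Read with a 7.7-fold lower number from compound 1 to compound 2 (0.89 log units; beyond the scatter), which adds a methoxy to the same ring, the two steps point the same way: among these compounds, more methoxy groups on this ring go with a lower number. The new step removes both methoxy groups and adds a fluorine in a single change, so it cannot show which part matters, and no measurement here explains the rise.

Still open, from the compounds shown here alone, is how the same ring would behave with one methoxy and no fluorine, or with no substituent at all. A hydroxyl or an amine on this ring also remains untested in the compounds shown.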